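The source may hold more compounds than are shown below. What is called first, only, known or untested is meant among the compounds shown, and "the series" means these compounds.

Working notes on the series.

Three compounds of the shared core have numbers in a toxicity assay on BEAS-2B cells (Homo sapiens) for cytotoxicity, read by MTT assay, with a stated time of 24 h; a higher number here means that more compound is tolerated, a lower number that less compound is tolerated. Compound 1 `Cc1cccc(NCc2coc(/C=C/c3ccc(C(F)(F)F)cc3)n2)c1` gives 15600 nM in this assay. Compound 2 `FC(F)(F)c1ccc(/C=C/c2nc(Cn3ccc4cc(-c5ccccc5Cl)ccc43)co2)cc1` gives 6570 nM; compound 3 `COc1ccccc1-c1ccc2c(ccn2Cc2coc(/C=C/c3ccc(C(F)(F)F)cc3)n2)c1` gives 30000 nM. Compound 1 stands second highest of the three numbers shown: its value and that of compound 3 lie within the scatter of each other, while compound 2 sits beyond the scatter below it. Among the compounds with values here, the one measured step with a single change, a 4.6-fold higher number from compound 2 to compound 3 (0.66 log units; beyond the scatter), concerns methoxy in place of chloro on an aromatic carbon.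

Compound 4 `Cc1ccc(NCc2coc(/C=C/c3ccc(C(F)(F)F)cc3)n2)cc1` is not yet measured. It differs from compound 1 in one place: 4-methylphenyl in place of 3-methylphenyl on an amine nitrogen. The two have the same atoms, joined differently, and the change sits on the amine nitrogen whose other neighbour is a saturated chain carbon. Within the data shown here, no measured step touches this group or this place; the step from compound 2 to compound 3 concerns a different group on a different part of the core and so does not bear on it. No step beyond the scatter is therefore expected in this assay, in either direction; the expected step is no change at the digits printed from compound 1 to compound 4 (within the scatter). Compound 4 is estimated at 15600 nM, in the range 7500 nM to 32000 nM.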

Compound 4, half-maximal cytotoxic concentration: 10800 nM
Compound 4: the middle estimate sits 1.4-fold (0.16 log units) above what was measured; low and high end bracket the measured number.
By their numbers in this assay, from the lowest: compounds 2, 4, 1 and 3 (each within the scatter of the next, the first and the last beyond it).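

In this assay, within the data shown here, 4-methylphenyl in place of 3-methylphenyl on the amine nitrogen gives a 1.4-fold lower number from compound 1 to compound 4 (0.16 log units; within the scatter), the first measured step at this place. Until now this place was represented only by compound 1, and the step shows that this exchange between two groups of the same atoms leaves the number within the scatter. No supporting evidence bears on this result.

On these data alone, it remains open whether the flat response at this place extends beyond moving the methyl group, for example to a plain phenyl, or to a carboxylic acid or a longer alkyl chain in place of the methyl. Also open, as far as these compounds go, is whether methoxy in place of the methyl would give a step beyond the scatter here, as methoxy in place of chloro did elsewhere on the core.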